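A few compounds are considered here, and "the series" means these few. Any claim that something is new, unique, unknown or untested is made for them only; others in the source may bear on it.

Compound 3 `COc1ccccc1/C=C/c1cccc(O)c1` gives 17 ug/mL in a functional assay on HT-29 cells (Homo sapiens) for inhibition, read by MTT assay, with a stated time of 2 days (a higher number here means a weaker inhibitor, a lower number a stronger inhibitor), which places it second highest of the three numbers measured, although its gaps to both of the others lie within the scatter. Compound 1 `Nc1cccc(/C=C/c2ccccc2)c1` gives 12.9 ug/mL in this assay, and compound 2 `Nc1cccc(/C=C/c2ccccc2O)c1` gives 30.4 ug/mL. Among the measured compounds shown here, the only measured step, a 2.4-fold higher number from compound 1 to compound 2 (0.37 log units; beyond the scatter), concerns hydroxy in place of hydrogen and does not match the change considered here. Compound 4 `COc1ccccc1/C=C/c1cccc(N)c1` differs from compound 3 by amino in place of hydroxy on an aromatic carbon. For the measured compounds named here, no measured pair shows amino in place of hydroxy, so these numbers offer no direct guide, and no step beyond the scatter is expected in this assay. Compound 4 is therefore estimated at 14 ug/mL, with a range from 6 ug/mL to 32 ug/mL. This expectation corresponds to a step of a 1.2-fold lower number from compound 3 to compound 4 (0.08 log units; within the scatter).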

Compound 4, half-maximal inhibitory concentration: 25.3 ug/mL
Compound 4: middle estimate off by 1.8-fold (0.26 log units), on the low side, and the stated range covers the measured number.
By their numbers in this assay, from the lowest: compounds 1, 3, 4 and 2 (each within the scatter of the next, the first and the last beyond it).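

Amino in place of hydroxy on an aromatic carbon, meta to a large group, gives a 1.5-fold higher number from compound 3 to compound 4 (0.17 log units; within the scatter) in this assay and so shows that this exchange leaves the number within the scatter. Methyl in place of hydrogen on an oxygen on an aromatic ring gives a 1.2-fold lower number from compound 2 to compound 4 (0.08 log units; within the scatter) and the gain of a methoxy group gives a 2.0-fold higher number from compound 1 to compound 4 (0.29 log units; within the scatter) in the same assay, so neither change separates compound 4 from its neighbours. Nothing available explains these results. As far as these compounds go, whether a carboxylic acid or a fluoro group in this place would give a step beyond the scatter remains open.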